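This account rests on a few compounds, and the source may have more. Where it says the series, first, only, none or still open, it means among the compounds named here.

Measured compounds in a functional assay on RD cells (Homo sapiens) for inhibition, read by MTT assay, with a stated time of 72 h; a lower number here means a stronger inhibitor, a higher number a weaker inhibitor:
- compound 1, `CN1C(=O)N(C)C2C1NC(=S)N2/N=C/C=C/c1ccccc1`: 46000 nM
- compound 2, `COc1ccc(/C=C/C=N/N2C(=S)NC3C2N(C)C(=O)N3C)cc1`: > 100000 nM, which is a limit of the assay, not a number
- compound 3, `CCN1C(=O)N(c2ccccc2)C2NC(=S)N(/N=C/C=C/c3ccccc3)C21`: 470 nM

Compound 1 and compound 2 differ by methoxy in place of hydrogen on an aromatic carbon. For the measured compounds named here, that change gave an at least 2.1-fold higher number from compound 1 to compound 2 (0.33 log units; beyond the scatter); the only evidence bearing on it is the limit of > 100000 nM in this assay, at which 1 of the 3 values shown sits. Compound 3 shares the same kind of core, but the difference between the two cores is not broken down here; in this assay compound 3 stands lowest of the two numbers, far apart from compound 1.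

Compound 4, `CCN1C(=O)N(c2ccccc2)C2NC(=S)N(/N=C/C=C/c3ccccc3OC)C21`, has not yet been measured. It differs from compound 3 by methoxy in place of hydrogen on an aromatic carbon. This is the same kind of change as that from compound 1 to compound 2, but not the same: there the methoxy sits para to a large group, here ortho to a large group. Resting only on the step seen with compound 1 and compound 2, the step expected from compound 3 is a 2.6-fold higher number from compound 3 to compound 4 (0.41 log units; beyond the scatter), a modest weakening. Compound 4 is therefore expected to give about 1200 nM, between 400 nM and 5000 nM.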

Compound 4, half-maximal inhibitory concentration: 45900 nM
The estimate for compound 4 lay 38-fold (1.58 log units) below the measured number; measured number above the stated range.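

In this assay, methoxy in place of hydrogen, ortho to a large group on the aromatic ring, gave a 98-fold higher number from compound 3 to compound 4 (1.99 log units; beyond the scatter) and so a much weaker inhibitor. In both pairs that carry this change the number goes up, so on these two cores the methoxy goes with weaker inhibition, and the two steps compare as follows: the same change on two cores in this assay, an at least 2.1-fold higher number (0.33 log units; beyond the scatter) from compound 1 to compound 2 and a 98-fold higher number (1.99 log units; beyond the scatter) from compound 3 to compound 4; the limit leaves it open whether they differ. As far as these compounds go, compound 2 stands at > 100000 nM and that is a limit of the assay, not a number, so the size of the earlier step stays unknown, the methoxy also sits in a different place on the ring in the two pairs, and nothing here shows that the change costs more on one core than on the other.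

The compounds shown leave open whether the loss belongs to the methoxy group itself or to its place on the ring. From the compounds shown here alone, it is also open how a hydroxy group, a fluorine atom or an amine in that same place would behave on the core of compound 3.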